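Hydrogen for fluoro on the urea-hydrazone aryl ring

A few compounds are considered here, and "the series" means these few. Any claim that something is new, unique, unknown or untested is made for them only; others in the source may bear on it.

In a functional assay on HepG2 cells (Homo sapiens) for antiproliferative activity, read by MTT assay, with a stated time of 72 h (a lower number here means a stronger inhibitor, a higher number a weaker inhibitor), compound 1 `O=C(N/N=C/c1ccc(O)cc1)Nc1ccc(Oc2ccnc3[nH]ccc23)c(F)c1` gives 1950 nM. Compound 2 `O=C(N/N=C/c1ccc(O)cc1)Nc1ccc(Oc2ccnc3[nH]ccc23)cc1` gives 32200 nM in this assay; it differs by hydrogen in place of fluoro on an aromatic carbon, and the step is a 17-fold higher number from compound 1 to compound 2 (1.22 log units; beyond the scatter). Compound 3 `CN(C)CCn1cccc1/C=N/NC(=O)Nc1ccc(Oc2ccnc3[nH]ccc23)c(F)c1` gives 8980 nM in this assay; its core differs from that of compound 1 by 1-(2-(dimethylamino)ethyl)-1H-pyrrol-2-yl in place of 4-hydroxyphenyl on a carbon with a double bond to nitrogen, with a step of a 4.6-fold higher number from compound 1 to compound 3 (0.66 log units; beyond the scatter). Compound 4 `CN(C)CCn1cccc1/C=N/NC(=O)Nc1ccc(Oc2ccnc3[nH]ccc23)cc1` is not yet measured and differs from compound 3 by hydrogen in place of fluoro on an aromatic carbon, the same change as that from compound 1 to compound 2, at a place described in identical terms. Going by these compounds, because that change gave a 17-fold higher number from compound 1 to compound 2 (1.22 log units; beyond the scatter), the step to compound 4 is expected to be an 8.9-fold higher number from compound 3 to compound 4 (0.95 log units; beyond the scatter), though this rests on a single pair and the carry-over to the other core is untested. Compound 4 is therefore estimated at 80000 nM in this assay, with a plausible range from 25000 nM to 250000 nM.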

Compound 4, half-maximal inhibitory concentration: "not active" (no number reported)
Compound 4 has no reported number here, so the estimate cannot be set against anything.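

Among the compounds shown here, compound 4 is reported as not active, without a number, so no step from compound 3 to compound 4 can be read. Going by these compounds, whether hydrogen in place of fluoro has the same size of effect on the core of compound 3 as on the core of compound 1 stays open. No supporting data bear on this result.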